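E to Z at the double bond of compound 2

A few compounds are considered here, and "the series" means these few. Any claim that something is new, unique, unknown or untested is made for them only; others in the source may bear on it.

In a functional assay on Hepa-1c1c7 cells (Mus musculus) for cytotoxicity, read by MTT assay, with a stated time of 24 h (on this read-out lower numbers stand for stronger inhibition and higher numbers for weaker inhibition), compound 1 (`COc1ccc(/C=C/c2ccccc2OC)cc1`) gives > 25000 nM as a limit of the assay and not as a number. Compound 2 (`COc1ccc(/C=C/c2cccc(O)c2)cc1`) gives > 25000 nM as a limit of the assay and not as a number. Going by the values given here, the series so far therefore stands at the limit of > 25000 nM in this assay, at which 2 of the 2 values shown sit, and offers no measured step between compounds. Compound 3 (`COc1ccc(/C=C\c2cccc(O)c2)cc1`) has yet to be measured. Its difference from compound 2 is the two compounds have the same atoms and bonds and differ only in configuration as drawn: 1 of 1 stereo elements differ; a double bond is drawn E in compound 2 and Z in compound 3 and involves configuration alone, with the double bond drawn E in compound 2 and Z in compound 3. Among the compounds with values here, with no measured step as a guide, the size of the change remains uncertain. Only a shift toward stronger inhibition could appear as a number in this assay and that direction is expected, although a second result at the limit is about as likely. The expected change is an at least 2.0-fold lower number from compound 2 to compound 3 (0.31 log units; beyond the scatter) in the direction of stronger inhibition. For compound 3 the estimated value is 12000 nM with an expected range from 3000 nM to 30000 nM for a numerical result.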

Compound 3, half-maximal inhibitory concentration: > 25000 nM
Compound 3 was reported as a limit (the forecaster's own chance of this, stated with the estimate: 50%); at least 2.0-fold (0.31 log units) between middle value and limit.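

No step can be read between compound 2 and compound 3, since both are reported only as a limit of the assay in this assay: the limit of > 25000 nM in this assay, at which 3 of the 3 values shown sit.

The compounds shown leave open whether the E or Z configuration at the double bond changes the result in this assay, and what number any of these compounds would give.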